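A Trifluoromethylphenyl Amide on the Shared Core

The source may hold more compounds than are shown below. What is called first, only, known or untested is meant among the compounds shown, and "the series" means these compounds.

The measured compounds in an assay on HL-60 cells for agonist activity at vitamin D3 receptor (Homo sapiens), read by microscopy, with a stated time of 96 h; a higher number here means that more compound is needed for the effect, a lower number that less compound is needed:
compound 1, `CCN(CC)CCNC(=O)c1ccc(C(CC)(CC)c2ccc(OCC(=O)C(C)(C)C)c(C)c2)n1CC`, gives 91 nM;
compound 2, `CC[C@@H](C)[C@H](NC(=O)c1ccc(C(CC)(CC)c2ccc(OCC(O)C(C)(C)C)c(C)c2)n1CC)C(=O)OC`, gives 26 nM;
compound 3, `CCn1c(C(=O)N(C)c2ccccc2)ccc1C(CC)(CC)c1ccc(OCC(O)C(C)(C)C)c(C)c1`, gives 6400 nM.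

Compound 1 stands second highest of the three numbers. Compound 2 lies below it, beyond the scatter, and compound 3 lies far above it, also beyond the scatter. Compound 4, `CCn1c(C(=O)Nc2cccc(C(F)(F)F)c2)ccc1C(CC)(CC)c1ccc(OCC(=O)C(C)(C)C)c(C)c1`, differs from compound 1 in one place: 3-(trifluoromethyl)phenyl in place of 2-(diethylamino)ethyl on an amide-type nitrogen. Among the measured compounds shown here, the only measured step that bears on this change is a 250-fold higher number from compound 2 to compound 3 (2.39 log units; beyond the scatter), where an aromatic ring entered on the amide nitrogen while the amide hydrogen was also replaced by methyl. For the measured compounds named here, compound 4 keeps its amide hydrogen, so only part of that step applies, and no measured pair isolates the aromatic ring alone. For compound 4 a moderate rise in the number is therefore expected, estimated as a 3.3-fold higher number from compound 1 to compound 4 (0.52 log units; beyond the scatter). Compound 4 is estimated at 300 nM, with a range from 60 nM to 1500 nM.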

Compound 4, half-maximal effective concentration: > 50000 nM
Compound 4: a limit, no number; the forecaster's own chance of this, stated with the estimate: 5%; at least 160-fold (2.22 log units) between middle value and limit.
By their numbers in this assay, from the lowest: compound 2; then compound 1; then compound 3. At a limit, above all of these: compound 4.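

In this assay, compound 4 gives no number, only a limit of the assay, > 50000 nM. The change on the amide-type nitrogen is an at least 540-fold higher number from compound 1 to compound 4 (2.73 log units; beyond the scatter), so this position can take a large rise with the amide hydrogen kept, whereas the earlier large rise, a 250-fold higher number from compound 2 to compound 3 (2.39 log units; beyond the scatter), came with that hydrogen replaced by methyl. The new step has only a floor, set by the assay: the limit of > 50000 nM in this assay, at which 1 of the 4 values shown sits.

The compounds shown leave open whether the rise follows the entering aromatic ring, its trifluoromethyl group or the departing diethylamino amine; a plain phenyl, a benzyl group or a 2-aminoethyl chain on the same nitrogen would separate these. Also open, going by these compounds, is whether a chain ending in a carboxylic acid would be tolerated at this position.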